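Chain variation at the ring nitrogen: two measured, one pending

The source may hold more compounds than are shown below. What is called first, only, known or untested is meant among the compounds shown, and "the series" means these compounds.

compound 1 `CCCCCCn1c(Cc2cc(OC)c(OC)c(OC)c2)nc2c(N)nc(F)nc21`: 112000000 nM
compound 2 `CC[C@H](C)Cn1c(Cc2cc(OC)c(OC)c(OC)c2)nc2c(N)nc(F)nc21`: 66700000 nM

In a functional assay on MCF7 cells (Homo sapiens) for cytotoxicity (a lower number here means that less compound is needed, a higher number that more compound is needed for the effect), compound 2 and compound 1 sit within the scatter of each other, the step between them being a 1.7-fold lower number from compound 1 to compound 2 (0.23 log units; within the scatter). Compound 3 `COc1cc(Cc2nc3c(N)nc(F)nc3n2CCOC(C)C)cc(OC)c1OC` carries isopropoxymethyl in place of sec-butyl on a saturated chain carbon bound to an aromatic nitrogen. Among the compounds with values here, the only measured step at that position, a 1.7-fold lower number from compound 1 to compound 2 (0.23 log units; within the scatter), was within the scatter; it is the sole precedent for altering this chain, and no step here has introduced an acceptor, so nothing beyond the scatter is expected in this assay. Compound 3 is estimated at 70000000 nM, range 20000000 nM to 250000000 nM, that is a 1.0-fold higher number from compound 2 to compound 3 (0.02 log units; within the scatter).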

Compound 3, half-maximal effective concentration: 769000000 nM
Beside the measured number, compound 3's estimate is 11-fold (1.04 log units) below it; the whole stated range lies below it.
By their numbers in this assay, from the lowest: compounds 2 and 1 (each within the scatter of the next); then compound 3.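

In this assay, within the data shown here, this chain position proves responsive to change: isopropoxymethyl in place of sec-butyl gives a 12-fold higher number from compound 2 to compound 3 (1.06 log units; beyond the scatter) and is the first step beyond the scatter. Isopropoxy in place of butyl gives a 6.9-fold higher number from compound 1 to compound 3 (0.84 log units; beyond the scatter) and points the same way, so compound 3 stands apart from both chains without oxygen. Nothing available bears on the reason for this rise.

On these data alone, whether the oxygen alone carries the step remains open, since the chain also differs in its branching. As far as these compounds go, how this assay would read an amine or a carboxylic acid on this chain also remains open.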